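Growing the Ring Substituent from Methyl to Isopropyl

This account rests on a few compounds, and the source may have more. Where it says the series, first, only, none or still open, it means among the compounds named here.

Three compounds have been measured in a functional assay on K562 cells (Homo sapiens) for cytotoxicity, read by thymidine incorporation, with a stated time of 48 h, tested at 10 ug/mL; a higher number here means more inhibition at the concentration tested (going by the name of the read-out), a lower number less inhibition:

Compound 1 `O=C1Nc2c(ncn2Cc2ccccc2)C(C#CC2CC2)N1Cc1ccccc1` gives 98%
Compound 2 `O=C1Nc2c(ncn2Cc2ccccc2)C(c2ccccc2)N1Cc1ccccc1` gives 90%
Compound 3 `CC1c2ncn(Cc3ccccc3)c2NC(=O)N1Cc1ccccc1` gives 98%

Compound 3 stands level with compound 1, the two sharing the highest number of the three; the step of no change at the digits printed from compound 1 to compound 3 (within the scatter) and the step of a number 8 percentage points higher from compound 2 to compound 3 (within the scatter) both lie within the scatter. Compound 4 `CC(C)C1c2ncn(Cc3ccccc3)c2NC(=O)N1Cc1ccccc1` differs from compound 3 only in this way: isopropyl in place of methyl on a saturated ring carbon. Every earlier exchange at this same carbon, a number 8 percentage points lower from compound 1 to compound 2 (within the scatter) as well as those just named, left the number within the scatter, so no step beyond the scatter is expected here either, a number 2 percentage points lower from compound 3 to compound 4 (within the scatter). Compound 4 is therefore estimated at 96%, within 88% to 100%.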

Compound 4, a percentage reported as inhibition, at one concentration (the size of the read-out at that concentration, not a potency): 51%
Compound 4: middle estimate off by 45 percentage points, on the high side; the whole stated range lies above it.
By their numbers in this assay, from the lowest: compound 4; then compounds 2, 1 and 3 (each within the scatter of the next).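

Isopropyl is the first group at this saturated ring carbon to move the number beyond the scatter in this assay (a number 47 percentage points lower from compound 3 to compound 4 (beyond the scatter)). The fall is just as clear against the two other groups (a number 39 percentage points lower from compound 2 to compound 4 (beyond the scatter); a number 47 percentage points lower from compound 1 to compound 4 (beyond the scatter)), so the number does not simply drop as the group grows: phenyl and 2-cyclopropylethynyl both hold more heavy atoms than isopropyl. Nothing available explains the drop.

The compounds shown leave open how ethyl, a straight propyl chain or tert-butyl would behave at this carbon. Whether isopropyl is a lone exception therefore stays unsettled.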